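The source may hold more compounds than are shown below. What is called first, only, known or untested is meant among the compounds shown, and "the series" means these compounds.

Measured compounds:
compound 1 `Nc1ccccc1NC(=O)c1ccc(CSC(=S)N2CCN(Cc3ccccn3)CC2)cc1`: 20.7%
compound 2 `Nc1ccccc1NC(=O)c1ccc(CSC(=S)N2CCN(C(c3ccccc3)c3ccccc3)CC2)cc1`: 8.7%
compound 3 `CN(Cc1ccncc1)C(=S)SCc1ccc(C(=O)Nc2ccccc2N)cc1`: 31.4%

All three were tested in a functional assay on A-375 cells (Homo sapiens) for antiproliferative activity, read by CCK-8 assay, with a stated time of 72 h, tested at 2 uM; a lower number here means a weaker effect, a higher number a stronger effect of the compound at the concentration tested. Compound 1 stands second highest of the three numbers: compound 3 lies above it and compound 2 lies below it, each beyond the usual scatter. Compound 4 `Nc1ccccc1NC(=O)c1ccc(CSC(=S)N2CCN(c3cccnc3)CC2)cc1` has not yet been measured in this assay. It differs from compound 1 in one place: pyridin-3-yl in place of (pyridin-2-yl)methyl on an amine nitrogen in a ring. Going by the values given here, no measured pair isolates this change, so what can be expected for the step from compound 1 to compound 4 rests only on the spread of the three numbers, which is narrow. A small step is expected, within the scatter and in no clear direction: a number 2.7 percentage points lower from compound 1 to compound 4 (within the scatter). Compound 4 is therefore estimated at 18%, with a range from 5% to 35%.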

Compound 4, a percentage reported as inhibition, at one concentration (the size of the read-out at that concentration, not a potency): 40.5%
Compound 4: middle estimate off by 22.5 percentage points, on the low side; measured number outside the range, above it.
By their numbers in this assay, from the lowest: compound 2; then compound 1; then compounds 3 and 4 (each within the scatter of the next).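

In this assay, the group on this ring nitrogen clearly matters: pyridin-3-yl in place of (pyridin-2-yl)methyl gives a number 19.8 percentage points higher from compound 1 to compound 4 (beyond the scatter). Both groups hold a six-membered aromatic ring with 1 hetero atom and have the same hydrogen-bond donor and acceptor counts, so those counts do not distinguish them. Nothing available explains the step.

The step combines two differences, the loss of the methylene link and the change from a pyridin-2-yl to a pyridin-3-yl ring, and the compounds shown do not separate them. A (pyridin-3-yl)methyl group on this nitrogen would test the link alone.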